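This account rests on a few compounds, and the source may have more. Where it says the series, first, only, none or still open, it means among the compounds named here.

Of the compounds shown here, three have been measured in an in vitro functional assay on cells (Fibroblast) for agonist activity at Alpha-1B adrenergic receptor (Homo sapiens) (on this read-out higher numbers stand for an effect only at larger amounts of compound and lower numbers for an effect already at smaller amounts), and a fourth awaits measurement. Compound 1 `Cn1ncnc1-c1ccccc1NCC1=NCCN1` gives 39.8 nM in this assay. Compound 2 `CCn1ncnc1-c1ccccc1NCC1=NCCN1` differs from compound 1 in one place, (methyl in place of hydrogen on a saturated chain carbon bound to an aromatic nitrogen), and compound 2 gives 63.1 nM in this assay; the step is a 1.6-fold higher number from compound 1 to compound 2 (0.20 log units; within the scatter). Compound 3 `Cn1cc(-c2ccccc2NCC2=NCCN2)cn1` carries a different core than compound 1, the difference being (1-methyl-1H-pyrazol-4-yl in place of 1-methyl-1H-1,2,4-triazol-5-yl on an aromatic carbon). For compound 3 this assay reports only a limit, < 100000 nM. Because the value of compound 3 sits at the limit of < 100000 nM in this assay, at which 1 of the 3 values shown sits, the step reads a step that the limit leaves unreadable from compound 1 to compound 3.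

Compound 4 `CCn1cc(-c2ccccc2NCC2=NCCN2)cn1` has not yet been measured in this assay. It stands to compound 3 as compound 2 stands to compound 1: the change is methyl in place of hydrogen on a saturated chain carbon bound to an aromatic nitrogen, the same change on the same kind of carbon. On the core of compound 1 this change produced a 1.6-fold higher number from compound 1 to compound 2 (0.20 log units; within the scatter), a step inside the usual scatter, so the same change on the core of compound 3 is expected to move the number little. Since compound 3 is known only as a limit, compound 4 is expected to come out as a step that the limit leaves unreadable from compound 3 to compound 4, and most likely this assay will again report only a limit for compound 4. The estimate for compound 4 is 30000 nM in this assay, with the expected range running from 3000 nM to 100000 nM.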

Compound 4, half-maximal effective concentration: < 100000 nM
Compound 4 gave a limit, no number (the forecaster's own chance of this, stated with the estimate: 70%); the middle value is on the limit's open side.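

Compound 3 and compound 4 can't be compared, because each is reported in this assay only as a limit of the assay and not as a number: the limit of < 100000 nM in this assay, at which 2 of the 4 values shown sit.

The compounds shown leave open whether methyl in place of hydrogen on a saturated chain carbon bound to an aromatic nitrogen moves the number at all on the core of compound 3, as no size can be read there.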